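Shrinking the Sulfonyl Substituent: Expected Stability of Compound 3

A few compounds are considered here, and "the series" means these few. Any claim that something is new, unique, unknown or untested is made for them only; others in the source may bear on it.

Compound 1 `CC(C)C(=O)NCCS(=O)(=O)NC(=O)c1ccc(Nc2nc(NC3(c4ccc(Cl)cc4)CC3)nc(OCC(F)(F)F)n2)cc1`: 86%
Compound 2 `O=C(NS(=O)(=O)c1ccccc1)c1ccc(Nc2nc(NC3(c4ccc(Cl)cc4)CC3)nc(OCC(F)(F)F)n2)cc1`: 100%

In an ADME assay on microsomes from liver (Homo sapiens) for metabolic stability, with a stated time of 10 min (a lower number here means that less of the compound is left, a higher number that more of the compound is left), compound 2 gives 100%, the highest of the two numbers shown, while compound 1 gives 86%. Compound 3 `CS(=O)(=O)NC(=O)c1ccc(Nc2nc(NC3(c4ccc(Cl)cc4)CC3)nc(OCC(F)(F)F)n2)cc1` differs from compound 2 by methyl in place of phenyl on a sulfonyl sulfur. Going by the values given here, the one measured step at this sulfonyl sulfur is a number 14 percentage points higher from compound 1 to compound 2 (beyond the scatter), where a chain gave way to phenyl. Among the compounds with values here, no measured step trades phenyl for methyl, so the direction stays open, and a modest step or none beyond the scatter in this assay is expected. Compound 3 is therefore expected to give 92%, ranging from 76% to 100%. This estimate means a step of a number 8 percentage points lower from compound 2 to compound 3 (within the scatter).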

Compound 3, percent of the compound remaining: 100%
The estimate for compound 3 lay 8 percentage points below the measured number; measured number inside the range.
By their numbers in this assay, from the lowest: compound 1; then compounds 2 and 3 (each within the scatter of the next).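

With methyl in place of phenyl on a sulfonyl sulfur, the data show no change at the digits printed from compound 2 to compound 3 (within the scatter) in this assay and so the aromatic ring is not required at this position to keep this read-out. Compound 3 also shows a number 14 percentage points higher from compound 1 to compound 3 (beyond the scatter) and so matches compound 2 in standing apart from the chain-bearing compound 1. No available evidence explains these numbers.

From the compounds shown here alone, whether an amine, a carboxylic acid or a plain longer alkyl chain on the sulfonyl sulfur would keep this read-out remains open. So does which part of the 2-((isopropylcarbonyl)amino)ethyl chain of compound 1 goes with its lower number.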